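The source may hold more compounds than are shown below. What is called first, only, known or untested is meant among the compounds shown, and "the series" means these compounds.

Within the data shown here, compound 3 `CCNCC(=O)N1N=C(c2cc3ccccc3oc2=O)CC1c1ccccc1` is one of three compounds measured in a functional assay on MGC-803 cells (Homo sapiens) for cytotoxicity, read by MTT assay, with a stated time of 48 h (on this read-out lower numbers stand for stronger inhibition and higher numbers for weaker inhibition), where compound 3 gives 26600 nM, the highest of the three numbers. Compound 1 `CC1=NN(C(=O)COc2ccc(Cl)cc2)C(c2cc(Br)ccc2O)C1` gives 23600 nM, which lies within the usual scatter of the number for compound 3, while compound 2 `C=CCN(CC=C)CC(=O)N1N=C(C)CC1c1cc(Br)ccc1O` gives 10200 nM, the lowest of the three and beyond the scatter from compound 3. Compound 4 `CC1CC(C)CN(CC(=O)N2N=C(c3cc4ccccc4oc3=O)CC2c2ccccc2)C1` has not yet been measured; it differs from compound 3 in one place: 3,5-dimethylpiperidin-1-yl in place of ethylamino on a saturated chain carbon bound to a carbonyl carbon. Among the measured compounds shown here, only one measured step touches the same place, a 2.3-fold lower number from compound 1 to compound 2 (0.36 log units; beyond the scatter), where a nitrogen-bearing group replaced an oxygen-bearing one on a saturated chain carbon bound to a carbonyl carbon. In compound 4 the nitrogen stays and only the groups attached to it change, so a step no larger than that one is expected, if anything toward a lower number. The expected step is a 1.8-fold lower number from compound 3 to compound 4 (0.25 log units; within the scatter). Compound 4 is estimated at 15000 nM, with a range from 5000 nM to 45000 nM.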

Compound 4, half-maximal inhibitory concentration: "not active" (no number reported)
Nothing numeric was reported for compound 4; no gap can be computed for the estimate.
By their numbers in this assay, from the lowest: compound 2; then compounds 1 and 3 (each within the scatter of the next).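

Among these compounds, compound 4 is reported as "not active" in this assay, with no number, so no step from compound 3 to compound 4 can be read. The compounds shown leave open how far 3,5-dimethylpiperidin-1-yl in place of ethylamino shifts the number. No available evidence bears on this result.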